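A few compounds are considered here, and "the series" means these few. Any claim that something is new, unique, unknown or untested is made for them only; others in the source may bear on it.

Working notes on the phenyl group of the series. In an ADME assay on microsomes from liver (Canis lupus familiaris) for metabolic stability (on this read-out higher numbers stand for a longer-lived compound and lower numbers for a shorter-lived compound), compound 1 `N#Cc1ccc(-c2nc(NCCNc3ccc([N+](=O)[O-])c(N)n3)ncc2-c2ncc[nH]2)cc1` gives > 0.5 h, which is a limit. Compound 2 `Nc1nc(NCCNc2ncc(-c3ncc[nH]3)c(-c3cc(F)ccc3F)n2)ccc1[N+](=O)[O-]` gives > 0.5 h, again a limit. Compound 3 `Nc1nc(NCCNc2ncc(-c3ncc[nH]3)c(-c3cc(F)ccc3Cl)n2)ccc1[N+](=O)[O-]` gives > 0.5 h, also a limit, so no number is available for it. The series as a whole stands at the limit of > 0.5 h in this assay, at which 3 of the 3 values shown sit.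

The next change leads to compound 4 `Nc1nc(NCCNc2ncc(-c3ncc[nH]3)c(-c3ccc(Cl)cc3F)n2)ccc1[N+](=O)[O-]`: 4-chloro-2-fluorophenyl in place of 2-chloro-5-fluorophenyl on an aromatic carbon. The exchanged phenyl group sits on an aromatic carbon ortho to a 1H-imidazol-2-yl group, and the two compounds have the same atoms, joined differently.

For the measured compounds named here, three measured steps bear on this change: a step that the two limits leave unreadable from compound 1 to compound 2, a step that the two limits leave unreadable from compound 1 to compound 3 and a step that the two limits leave unreadable from compound 2 to compound 3. None of them gives a size, so the series offers no measured effect of a phenyl exchange to carry over. No step beyond the scatter is therefore expected in this assay, and no direction is expected either. The estimated outcome is a step that the limit leaves unreadable from compound 3 to compound 4. Another limit is the likeliest report, as with compound 3 at > 0.5 h. For compound 4 the estimated half-life is 0.7 h, with an expected range from 0.4 h to 1.5 h.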

Compound 4, half-life: > 0.5 h
Compound 4 ended at the assay's limit; the forecaster's own chance of this, stated with the estimate: 70%; the middle value lies beyond the limit too.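

For the compounds shown here, no step from compound 1, compound 2 or compound 3 to compound 4 can be read in this assay, and all four compounds stay at the same limit: the limit of > 0.5 h in this assay, at which 4 of the 4 values shown sit. The compounds shown leave open how long the half-life of each compound actually is, and whether any exchange of the phenyl group changes it.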